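Halogen exchange on the phenyl of the piperidinyl series

The source may report more compounds than this note shows. Statements on the series, on what has been measured and on what is new or still open speak of the compounds shown alone.

Compound 1 `c1ccc(CNc2ccc3nc(-c4ccccc4)oc3n2)cc1` gives "not determined" (no result reported) in an assay on isolated protein for inhibition of Amine oxidase [flavin-containing] B (Homo sapiens), read by fluorescence, with a stated time of 1 h; on this read-out lower numbers stand for stronger inhibition and higher numbers for weaker inhibition. Compound 2 `c1ccc(-c2nc3ccc(N4CCCCC4)nc3o2)cc1` gives 1370 nM in this assay. Compound 3 `Fc1cccc(-c2nc3ccc(N4CCCCC4)nc3o2)c1` gives 272 nM in this assay and holds the lowest of the two numbers shown, with compound 2 nearest; the step of a 5.0-fold lower number from compound 2 to compound 3 (0.70 log units; beyond the scatter) lies beyond the scatter. Compound 4 `Clc1ccc(-c2nc3ccc(N4CCCCC4)nc3o2)cc1` differs from compound 3 by 4-chlorophenyl in place of 3-fluorophenyl on an aromatic carbon. Going by the values given here, no measured step exchanges one halogen for another or moves a substituent around this phenyl, so the only step that bears on the change is a 5.0-fold lower number from compound 2 to compound 3 (0.70 log units; beyond the scatter), which concerns a halogen added to the same phenyl; whether a different halogen at a different position gives the same number is unknown from these compounds. Compound 4 is therefore expected to stay close to compound 3, and the step of a 1.1-fold higher number from compound 3 to compound 4 (0.04 log units; within the scatter) in this assay is estimated to lie within the scatter, with a wide range on either side. Compound 4 is estimated at 300 nM, between 80 nM and 1200 nM.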

Compound 4, half-maximal inhibitory concentration: 890 nM
Estimate against measurement, compound 4: 3.0-fold (0.47 log units) below; the measured number falls inside the stated range.
By their numbers in this assay, from the lowest: compound 3; then compounds 4 and 2 (each within the scatter of the next).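

In this assay, a halogen on this phenyl does not by itself lower the number: chloro in place of hydrogen gives a 1.5-fold lower number from compound 2 to compound 4 (0.19 log units; within the scatter), whereas fluoro in place of hydrogen gave a 5.0-fold lower number from compound 2 to compound 3 (0.70 log units; beyond the scatter). The exchange of 3-fluorophenyl for 4-chlorophenyl gives a 3.3-fold higher number from compound 3 to compound 4 (0.51 log units; beyond the scatter), so among these compounds only the 3-fluorophenyl stands apart from the unsubstituted phenyl. Nothing on hand explains this difference.

The exchange alters both the halogen and its place on the phenyl, so the two contributions cannot be separated here; 3-chlorophenyl and 4-fluorophenyl would be the matching pair to do so. Going by these compounds, whether the number at this phenyl responds to non-halogen groups, such as methoxy or nitrile, also remains open.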